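Nitro in place of methoxy on the aryl oxadiazole

The source may report more compounds than this note shows. Statements on the series, on what has been measured and on what is new or still open speak of the compounds shown alone.

Of the compounds shown here, three built on the same core have been tested in a functional assay on HeLa cells (Homo sapiens) for antiproliferative activity, read by MTT assay, with a stated time of 24 h; a lower number here means a stronger inhibitor, a higher number a weaker inhibitor. Compound 1 `O=[N+]([O-])c1ccc(Cc2nnc(Cn3nnc4ccccc43)o2)cc1` carries a nitro group and a methylene link and gives 157000 nM. Compound 2 `Brc1ccc(-c2nnc(Cn3nnc4ccccc43)o2)cc1`, with a bromo substituent, gives 305000 nM, and compound 3 `COc1ccc(-c2nnc(Cn3nnc4ccccc43)o2)cc1`, with a methoxy substituent, gives 269000 nM. Compound 3 thus sits with its number between those of compound 2 and compound 1, and both lie within the usual scatter of it.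

Among the measured compounds shown here, the only single-point step among the measured compounds is a 1.1-fold lower number from compound 2 to compound 3 (0.05 log units; within the scatter), which shows no effect beyond the scatter. Compound 4 `O=[N+]([O-])c1ccc(-c2nnc(Cn3nnc4ccccc43)o2)cc1` is the next member: nitro in place of methoxy on an aromatic carbon. For the measured compounds named here, no single-point step joins compound 3 to compound 1, which already carries a nitro group; compound 1 gives 157000 nM, and this number can only be read as showing that a nitro group on a related core gave a number in the same region as the others.

Given that the step from compound 2 to compound 3 was within the scatter, the change to compound 4 is expected to be a 1.3-fold lower number from compound 3 to compound 4 (0.11 log units; within the scatter), with no movement beyond the scatter. The estimate for compound 4 in this assay is 210000 nM, within a range from 100000 nM to 450000 nM.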

Compound 4, half-maximal inhibitory concentration: 299000 nM
The estimate for compound 4 lay 1.4-fold (0.15 log units) below the measured number; low and high end bracket the measured number.
By their numbers in this assay, from the lowest: compounds 1, 3, 4 and 2 (each within the scatter of the next).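

In this assay, nitro in place of methoxy on this aromatic carbon, para to a large group, gives a 1.1-fold higher number from compound 3 to compound 4 (0.05 log units; within the scatter), and nitro in place of bromo at the same carbon gives a 1.0-fold lower number from compound 2 to compound 4 (0.01 log units; within the scatter). Read with a 1.1-fold lower number from compound 2 to compound 3 (0.05 log units; within the scatter), these steps now join all three substituents directly, and none of the three steps leaves the scatter, so bromo, methoxy and nitro at this position cannot be told apart in this assay, which the single step between compound 2 and compound 3 could not show for nitro. No supporting information is available that could account for this flat result.

Whether any group at this carbon can move the number beyond the scatter stays open, since an amine, a carboxylic acid or a longer chain there is not among the compounds shown. Among the compounds shown here, also open is what the methylene link contributes, as compound 1 gives 157000 nM and compound 4 gives 299000 nM, but no step between the two can be read here.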